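The compounds below may be only part of what the source reports. "The series", "measured", "known", "first", "only" and "open" are said of these compounds alone.

Measured so far in a functional assay on MCF7 cells (Homo sapiens) for cytotoxicity, read by MTT assay, with a stated time of 72 h; on this read-out higher numbers stand for weaker inhibition and lower numbers for stronger inhibition:
compound 1, `O=C(Nc1ccc(Oc2ccnc3[nH]ccc23)cc1)c1nn(-c2ccc(Cl)cc2)ccc1=O`: 10600 nM
compound 2, `O=C(Nc1ccc(Oc2ccnc3[nH]ccc23)cc1)c1nn(-c2ccc(Br)cc2)ccc1=O`: 7890 nM
compound 3, `O=C(Nc1ccc(Oc2ccnc3[nH]ccc23)c(F)c1)c1nn(-c2ccc(Cl)cc2)ccc1=O`: > 60000 nM

Compound 1 and compound 2 share one core and differ only in one halogen on the phenyl ring; the step of a 1.3-fold lower number from compound 1 to compound 2 (0.13 log units; within the scatter). For compound 3 the value > 60000 nM is a limit of this assay, not a number. Compound 3 thus stands at the weak end of what has been measured, and the step of an at least 5.6-fold higher number from compound 1 to compound 3 (0.75 log units; beyond the scatter). This rests on (the limit of > 60000 nM in this assay, at which 1 of the 3 values shown sits).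

Compound 4 `O=C(Nc1ccc(Oc2ccnc3[nH]ccc23)c(F)c1)c1nn(-c2ccc(Br)cc2F)ccc1=O` has not yet been tested. Compared with compound 3, the change is 4-bromo-2-fluorophenyl in place of 4-chlorophenyl on an aromatic nitrogen. Of the measured steps, only the exchange of chloro for bromo has a counterpart, from compound 1 to compound 2, and that exchange stayed within the scatter. The added fluoro on the phenyl ring has no measured counterpart among these compounds. The expected step is therefore a number no higher from compound 3 to compound 4 (the limit leaves the size open), that is, none beyond the scatter. Compound 4 is estimated at 60000 nM, with a range from 20000 nM to 200000 nM, and the assay may again report only a limit.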

Compound 4, half-maximal inhibitory concentration: 23500 nM
For compound 4 the middle estimate is 2.6-fold (0.41 log units) above the measured one; the range from low to high includes it.
By their numbers in this assay, from the lowest: compounds 2 and 1 (each within the scatter of the next); then compound 4. At a limit, above all of these: compound 3.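

In this assay, the change on the aromatic nitrogen from 4-chlorophenyl to 4-bromo-2-fluorophenyl gives an at least 2.5-fold lower number from compound 3 to compound 4 (0.40 log units; beyond the scatter). Going by these compounds alone, this is the first step at this phenyl ring that clears the usual scatter, as the only earlier change there, a 1.3-fold lower number from compound 1 to compound 2 (0.13 log units; within the scatter), did not, so the ring is not indifferent to substitution once the compound carries the fluoro of compound 3. The step can be read only as a minimum, because compound 3 carries a limit and not a number: the limit of > 60000 nM in this assay, at which 1 of the 4 values shown sits.

The compounds shown leave open how this step divides between the bromo and the added fluoro, which enter together here, and whether the same change would move the number on the core of compound 1. Also open, going by these compounds, is how this position would respond to a group of a different kind on the phenyl ring, such as an amine or a carboxylic acid, in place of the halogens seen so far.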